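This account rests on a few compounds, and the source may have more. Where it says the series, first, only, none or still open, it means among the compounds named here.

Measured in a functional assay on HCT-15 cells (Homo sapiens) for cytotoxicity; on this read-out lower numbers stand for an effect already at smaller amounts and higher numbers for an effect only at larger amounts of compound:
compound 1 `CCCCC/C=C\C[C@@H](O)[C@H](O)/C=C/[C@@H]1C/C=C\CCCC(=O)O1` — 14.7 ug/mL
compound 2 `CCCCC/C=C\C[C@H](O)C(/C=C/[C@@H]1C/C=C\CCCC(=O)O1)OC` — 4.6 ug/mL

Of the two numbers in this assay, compound 2 gives the lowest, with 4.6 ug/mL; its nearest neighbour is compound 1 at 14.7 ug/mL, which is a gap beyond the usual scatter. Going by the values given here, no single-site step between measured compounds is available, so there is no directly comparable precedent for the change from compound 2 to compound 3 `CC/C=C\C/C=C\C[C@H](O)C(/C=C/[C@@H]1C/C=C\CCCC(=O)O1)OC`.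

The change is but-1-en-1-yl in place of butyl on a saturated chain carbon bound to a double-bonded chain carbon. The rest of the structure, including the methoxy group and the lactone, is kept. Among the compounds with values here, with no measured step of this kind to lean on, only a small step is expected in this assay, with no clear direction, and it is expected to stay within the usual scatter: a 1.0-fold lower number from compound 2 to compound 3 (0.01 log units; within the scatter). Compound 3 is accordingly estimated at 4.5 ug/mL, with a range from 2 ug/mL to 10 ug/mL.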

Compound 3, concentration for half-maximal effect: 4.4 ug/mL
The estimate for compound 3 lay 1.0-fold (0.01 log units) above the measured number; measured number inside the range.
By their numbers in this assay, from the lowest: compounds 3 and 2 (each within the scatter of the next); then compound 1.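

In this assay, but-1-en-1-yl in place of butyl on a saturated chain carbon bound to a double-bonded chain carbon gives a 1.0-fold lower number from compound 2 to compound 3 (0.02 log units; within the scatter), the first single-site step available in this series. At this position, therefore, the one added double bond outside aromatic rings leaves the read-out within the usual scatter, although this single pair says nothing about other changes at the same site. No evidence is available that bears on the reason for this result.

On these data alone, whether a longer chain or a terminal carboxylic acid at this position would also stay close to compound 2 remains open. Compound 1 and compound 2 differ in more than one place, so the separate contribution of the methoxy group cannot be read from their values.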